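From ethylcarbamoyl to methylcarbamoyl: one small step

The source may report more compounds than this note shows. Statements on the series, on what has been measured and on what is new or still open speak of the compounds shown alone.

Values so far in a physicochemical assay for lipophilicity, at pH 7.4 (on this read-out lower numbers stand for lower lipophilicity and higher numbers for higher lipophilicity), for two compounds:
compound 1 `CNC(=O)c1ccc(=O)n(Cc2cc(Br)ccc2F)c1` gives 2.6
compound 2 `CCNC(=O)c1cc(C(=O)NC)c(=O)n(Cc2ccccc2)c1` gives 3

Of these two, compound 2 stands higher, and compound 1 lies lower by a gap beyond the usual scatter. Compound 3 `CNC(=O)c1cc(C(=O)NC)c(=O)n(Cc2ccccc2)c1` has not yet been measured. It differs from compound 2 in one place (hydrogen in place of methyl on a saturated chain carbon bound to an amide-type nitrogen), with hydrogen in place of methyl on a saturated chain carbon bound to an amide-type nitrogen, which also reads as ethylcarbamoyl to methylcarbamoyl. For the measured compounds named here, no two measured compounds differ in only one place, so the data offer no direct guide to the size of this step. In this assay a modest move to a lower number is expected, slightly beyond the scatter. The estimated shift (a number 0.40 log units lower from compound 2 to compound 3 (beyond the scatter)) is small. For compound 3 the expected value is 2.6 with an estimated range from 2.3 to 2.9 for a measurement of this kind.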

Compound 3, distribution coefficient: 2.4
Estimate against measurement, compound 3: 0.20 log units above; the measured number falls inside the stated range.
By their numbers in this assay, from the lowest: compounds 3 and 1 (each within the scatter of the next); then compound 2.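

In this assay, the change from ethylcarbamoyl to methylcarbamoyl amounts to a number 0.60 log units lower from compound 2 to compound 3 (beyond the scatter), the only step shown so far between compounds that differ in one place. For the compounds shown here, this gives the position a measured size of change, which the earlier compounds, differing in several places, could not provide: the loss of a single carbon, hydrogen in place of methyl on a saturated chain carbon bound to an amide-type nitrogen, is enough to carry the number past the scatter. No measurement shown accounts for the size of this step.

As far as these compounds go, how the number would respond to a longer chain such as propyl, or to an amine or a carboxylic acid at this place, remains open. From the compounds shown here alone, whether the same change has a similar size on a different core also remains open, as it is read here in one pair only.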